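The source may report more compounds than this note shows. Statements on the series, on what has been measured and on what is new or still open speak of the compounds shown alone.

Measured so far:
- compound 1, `CC(C)[C@H](NC(=O)COc1cccc2ccccc12)C(=O)N[C@@H](CC(=O)O)C(=O)CSc1nc2ccccc2o1`: in a functional assay on Jurkat cells (Homo sapiens) for inhibition (on this read-out higher numbers stand for weaker inhibition and lower numbers for stronger inhibition), compound 1 gives > 200000 nM, which is a limit of the assay and not a number.
- compound 2, `CC(C)[C@H](NC(=O)COc1cccc2ccccc12)C(=O)N[C@@H](CC(=O)O)C(=O)CSc1nc2ccccc2s1`: in this assay compound 2 gives > 200000 nM, again a limit of the assay and not a number.

Among the measured compounds shown here, compound 2 therefore stands at the upper limit of this assay, as does the only other measured compound (the limit of > 200000 nM in this assay, at which 2 of the 2 values shown sit). For the measured compounds named here, the single step between measured compounds, a step that the two limits leave unreadable from compound 1 to compound 2, cannot be read in size or direction because both ends are limits.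

Compound 3, `Cc1cc(OCC(=O)[C@H](CC(=O)O)NC(=O)[C@@H](NC(=O)COc2cccc3ccccc23)C(C)C)nc(C)n1`, differs from compound 2 in one place: (2,6-dimethylpyrimidin-4-yl)oxy in place of (1,3-benzothiazol-2-yl)sulfanyl on a saturated chain carbon bound to a carbonyl carbon. Going by the values given here, no measured step bears on this change in readable form, and the one step that is known leaves no direction to carry over. The expectation for compound 3 rests only on the position of compound 2 at the limit and on the size of the structural change.

Compound 3 is estimated at 200000 nM, with a range from 20000 nM to 2000000 nM, and the expected step of a number no higher from compound 2 to compound 3 (the limit leaves the size open) is set at no change beyond the scatter, with a wide range to either side.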

Compound 3, half-maximal inhibitory concentration: > 200000 nM
Compound 3: a limit, no number (the forecaster's own chance of this, stated with the estimate: 60%); the middle value sits exactly at the limit.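

In this assay compound 3 gives > 200000 nM, a limit of the assay and not a number. No step among compound 1, compound 2 and compound 3 can be read, in size or direction, because all three stand at the same limit: the limit of > 200000 nM in this assay, at which 3 of the 3 values shown sit.

The compounds shown leave open how (1,3-benzoxazol-2-yl)sulfanyl, (1,3-benzothiazol-2-yl)sulfanyl and (2,6-dimethylpyrimidin-4-yl)oxy rank against one another in this assay.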